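The source may hold more compounds than are shown below. What is called first, only, known or untested is meant among the compounds shown, and "the series" means these compounds.

Of the compounds shown here, three of the shared core have been measured in an ADME assay on L02 cells (Homo sapiens) for inhibition, read by CCK-8 assay, with a stated time of 48 h; a higher number here means a weaker inhibitor of growth, a lower number a stronger inhibitor of growth. Compound 1 `Cc1ccccc1Nc1nc(NC2CC2)ncc1Cl` gives > 100000 nM, which is a limit of the assay rather than a number. Compound 2 `Cc1ccccc1Nc1nc(NC2CCCCC2)ncc1Cl` likewise gives > 100000 nM, again a limit and not a number. The step that the two limits leave unreadable from compound 1 to compound 2 therefore cannot be read in size. Going by the values given here, compound 3 `CN1CCN(c2ccc(Nc3ncc(Cl)c(Nc4ccccc4)n3)nc2)CC1` is the only compound to give a number, 7990 nM in this assay, and so it stands alone as the single point from which compound 4 can be judged. The other two values both sit at the limit of > 100000 nM in this assay, at which 2 of the 3 values shown sit.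

Compound 4 `Cc1cc(C)c(Nc2nc(Nc3ccc(N4CCN(C)CC4)cn3)ncc2Cl)c(C)c1` differs from compound 3 in one place: 2,4,6-trimethylphenyl in place of phenyl on a nitrogen on an aromatic ring. Among the compounds with values here, none of the measured steps touches this change, since the only step recorded concerns a different change and is unreadable in size. Within the data shown here, with no measured step bearing on the change, the expectation is that compound 4 stays close to compound 3 in this assay, and the step of a 1.0-fold higher number from compound 3 to compound 4 (0.00 log units; within the scatter) is estimated as no larger than the usual scatter. Compound 4 is therefore expected to give about 8000 nM in this assay, within a range from 2500 nM to 30000 nM.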

Compound 4, concentration for 50% growth inhibition: 20500 nM
For compound 4 the middle estimate is 2.6-fold (0.41 log units) below the measured one, within the range that was stated.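

In this assay, going by these compounds alone, the replacement of phenyl by 2,4,6-trimethylphenyl gives a 2.6-fold higher number from compound 3 to compound 4 (0.41 log units; beyond the scatter), the first step in this set whose size can be read and the first to touch the group on this nitrogen on an aromatic ring. It shows that this place is not silent in this assay: the larger group, with 9 heavy atoms in place of 6, moves the number modestly upward, to a weaker inhibitor of growth, although it brings no hydrogen-bond donor, no hydrogen-bond acceptor and no net charge. Even so, compound 4 gives a number, as compound 3 does, and so joins neither of the compounds held at a limit: the limit of > 100000 nM in this assay, at which 2 of the 4 values shown sit.

This single pair cannot tell whether the step is a matter of the whole 2,4,6-trimethylphenyl group or of only part of it, and it gives no cause for the step. On these data alone, how a methoxyphenyl group, a benzyl group or a phenyl ring carrying a carboxylic acid would read on the same nitrogen stays open, as does whether any such group would move the number the other way.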